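Swapping tert-butyl for 1-phenylethyl in a level ester pair

This account rests on a few compounds, and the source may have more. Where it says the series, first, only, none or still open, it means among the compounds named here.

- compound 1 `CCCCCC(=O)OC1C(C(O)CO)OC2OC(C)(C)OC21`: 1200000 nM
- compound 2 `CC(C)(C)CC(=O)OC1C(C(O)CO)OC2OC(C)(C)OC21`: 1200000 nM

In a functional assay on K562 cells (Homo sapiens) for inhibition (on this read-out higher numbers stand for weaker inhibition and lower numbers for stronger inhibition), compound 2 gives 1200000 nM, level with compound 1 at the digits shown. Compound 3 `CC(CC(=O)OC1C(C(O)CO)OC2OC(C)(C)OC21)c1ccccc1` alters the same place, a saturated chain carbon bound to a carbonyl carbon: 1-phenylethyl in place of tert-butyl on a saturated chain carbon bound to a carbonyl carbon. Within the data shown here, one measured step bears on this change, tert-butyl in place of butyl, and it reads no change at the digits printed from compound 1 to compound 2 (within the scatter). Among the measured compounds shown here, it is a thin guide: no measured compound carries an aromatic ring at this place. Resting on that step and on compound 2 at 1200000 nM, no move beyond the scatter is expected in this assay, in either direction. The expected step is a 1.3-fold lower number from compound 2 to compound 3 (0.12 log units; within the scatter). Compound 3 is estimated at 900000 nM, with an expected range of 350000 nM to 1600000 nM.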

Compound 3, half-maximal inhibitory concentration: 500000 nM
Compound 3: the middle estimate sits 1.8-fold (0.26 log units) above what was measured, within the range that was stated.
By their numbers in this assay, from the lowest: compound 3; then compounds 1 and 2 (each within the scatter of the next).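

In this assay, the place on a saturated chain carbon bound to a carbonyl carbon proves able to move the read-out: 1-phenylethyl in place of tert-butyl brings a 2.4-fold lower number from compound 2 to compound 3 (0.38 log units; beyond the scatter) and, in place of butyl, brings a 2.4-fold lower number from compound 1 to compound 3 (0.38 log units; beyond the scatter) at the same place. The earlier pair had shown only butyl and tert-butyl reading level, so this is the first step here beyond the scatter, though a modest one, and it comes with the first six-membered aromatic ring at this place. Nothing measured accounts for this step.

The compounds shown leave open whether the step belongs to the aromatic ring itself or simply to the larger group, which a cyclohexyl group in the same place could separate. They also leave open how an amine or a carboxylic acid on that ring would read.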